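Cyclohexyl in place of 5-chlorothiophen-2-yl: compound 4

This account rests on a few compounds, and the source may have more. Where it says the series, first, only, none or still open, it means among the compounds named here.

Three compounds have been measured in an assay on isolated protein for binding affinity to sphingosine 1-phosphate receptor 2 (Homo sapiens), read by surface plasmon resonance; on this read-out lower numbers stand for tighter binding and higher numbers for weaker binding:

compound 1 `Cn1nc(C(F)(F)F)c2c(-c3ccccc3)cc(NNC(=O)Nc3cc(Cl)nc(Cl)c3)nc21`: 940 nM
compound 2 `Cc1nn(C)c2nc(NNC(=O)Nc3cc(Cl)nc(Cl)c3)cc(-c3ccc(Cl)s3)c12`: 1980 nM
compound 3 `Cn1ncc2c(-c3ccc(F)cc3)cc(NNC(=O)Nc3cc(F)cc(F)c3)nc21`: 3980 nM

Compound 2 holds the second highest of the three numbers. Its value and that of compound 3 lie within the usual scatter of each other, so no order between them can be read. Compound 1 gives a lower number, and that gap lies beyond the scatter.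

Compound 4 `Cc1nn(C)c2nc(NNC(=O)Nc3cc(Cl)nc(Cl)c3)cc(C3CCCCC3)c12` differs from compound 2 in one place: cyclohexyl in place of 5-chlorothiophen-2-yl on an aromatic carbon. For the measured compounds named here, no measured pair shows this change, so the expected step of a 1.3-fold higher number from compound 2 to compound 4 (0.10 log units; within the scatter) is small and within the scatter, with no clear direction. Compound 4 is expected to give about 2500 nM in this assay, somewhere between 1000 nM and 6500 nM.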

Compound 4, dissociation constant: 2010 nM
For compound 4 the middle estimate is 1.2-fold (0.09 log units) above the measured one, and the stated range covers the measured number.
By their numbers in this assay, from the lowest: compound 1; then compounds 2, 4 and 3 (each within the scatter of the next).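

Putting cyclohexyl in place of 5-chlorothiophen-2-yl swaps an aromatic ring holding sulfur and chlorine for a non-aromatic ring of carbon only, yet this assay shows a 1.0-fold higher number from compound 2 to compound 4 (0.01 log units; within the scatter) as its step. For this pair, then, an aromatic ring on this carbon, opposite the ring nitrogen, is not needed to keep the number at this level. Nothing available bears on the reason for this result.

Still open, going by these compounds, is whether a group of another kind here, such as an amine, a carboxylic acid or a longer carbon chain, would move the number beyond the scatter.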